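The source may report more compounds than this note shows. Statements on the series, on what has been measured and on what is new or still open speak of the compounds shown alone.

Measured in a physicochemical assay for solubility, read by LC-MS, in phosphate buffer, with a stated time of 24 h, at pH 7.4; on this read-out lower numbers stand for lower solubility and higher numbers for higher solubility:
- compound 1 `O=C(Nc1ccccc1)c1cnc(NCc2c(F)ccc3c2CCO3)n2cnnc12`: < 1000 nM
- compound 2 `O=C1c2ccccc2CN1c1cnc(NCc2c(F)ccc3c2CCO3)n2cnnc12`: 4000 nM

Among the measured compounds shown here, compound 2 stands at 4000 nM, the only true number so far. The value of compound 1, < 1000 nM, is a limit. Compound 3 `CN(C)Cc1ccc2c(c1)CN(c1cnc(NCc3c(F)ccc4c3CCO4)n3cnnc13)C2=O` differs from compound 2 by (dimethylamino)methyl in place of hydrogen on an aromatic carbon. For the measured compounds named here, only one measured step exists, an at least 4.0-fold higher number from compound 1 to compound 2 (0.60 log units; beyond the scatter), and it involved a different change, so it bears only loosely. A modest rise is nevertheless expected, an estimated 2.0-fold higher number from compound 2 to compound 3 (0.30 log units; within the scatter). For compound 3 the estimated value is 8000 nM, with an expected range of 2000 nM to 35000 nM.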

Compound 3, solubility: 12000 nM
For compound 3 the middle estimate is 1.5-fold (0.18 log units) below the measured one; low and high end bracket the measured number.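

In this assay, (dimethylamino)methyl in place of hydrogen on an aromatic carbon gives a 3.0-fold higher number from compound 2 to compound 3 (0.48 log units; beyond the scatter), a step beyond the usual scatter. The earlier step exchanged a whole group on the shared core, whereas this one shows that the number also moves with a single addition to the six-membered aromatic ring of that group. Nothing shown gives a reason for this rise.

From the compounds shown here alone, whether a cyclic amine such as morpholine, a carboxylic acid or a longer chain at this place would give a similar number remains open. So does the outcome of placing (dimethylamino)methyl on another carbon of this ring.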